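Adding a Third Fluorine to an Already Tolerated Aryl Group

A few compounds are considered here, and "the series" means these few. Any claim that something is new, unique, unknown or untested is made for them only; others in the source may bear on it.

Three compounds built on one shared core differ only in the aromatic group at one end: compound 1 `C[C@]1(CN2CCc3oc(-c4ccc(F)cc4)cc3C2)Cn2cc([N+](=O)[O-])nc2O1`, compound 2 `C[C@]1(CN2CCc3nc(-c4ccc(C(F)(F)F)cc4)ccc3C2)Cn2cc([N+](=O)[O-])nc2O1` and compound 3 `C[C@]1(CN2CCc3nc(-c4ccc(F)c(F)c4)ccc3C2)Cn2cc([N+](=O)[O-])nc2O1`. In an ADME assay on Vero cells (Chlorocebus sabaeus) for cytotoxicity, read by MTT assay, with a stated time of 72 h (a lower number here means that less compound is tolerated, a higher number that more compound is tolerated), compound 1 gives "not determined" (no result reported). Compound 2 reaches the limit of this assay, giving > 32 ug/mL. Compound 3 also reaches the limit of this assay, giving > 32 ug/mL. With both ends at a limit, the step that the two limits leave unreadable from compound 2 to compound 3 has no readable size. Compound 3 thus stands where the measurements stop: it shares the limit of > 32 ug/mL in this assay, at which 2 of the 3 values shown sit, with compound 2, and compound 1 contributes no number.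

Compound 4 `C[C@]1(CN2CCc3nc(-c4cc(F)c(F)c(F)c4)ccc3C2)Cn2cc([N+](=O)[O-])nc2O1` differs from compound 3 by fluoro in place of hydrogen on an aromatic carbon, read one bond further out as 3,4-difluorophenyl to 3,4,5-trifluorophenyl. For the measured compounds named here, the only measured step, a step that the two limits leave unreadable from compound 2 to compound 3, exchanged one aromatic group for another and stayed at the limit, so it gives no size to build on. Compound 4 is therefore expected to stay at the limit as well, with an estimated step that the limit leaves unreadable from compound 3 to compound 4 of nothing beyond the scatter. The estimate for compound 4 in this assay is 45 ug/mL, within 25 ug/mL to 100 ug/mL.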

Compound 4, half-maximal cytotoxic concentration: > 32 ug/mL
Compound 4: only a limit was reported (the forecaster's own chance of this, stated with the estimate: 85%); the middle value is on the limit's open side.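

Compound 2, compound 3 and compound 4 all stop at a limit in this assay, so no step among them can be read: the limit of > 32 ug/mL in this assay, at which 3 of the 4 values shown sit.

The compounds shown leave open how much of each compound the cells tolerate, and whether these aromatic groups differ at all.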